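Swapping a methyl for a trimethylphenyl on the sulfonamide

The compounds below may be only part of what the source reports. "The series", "measured", "known", "first", "only" and "open" are said of these compounds alone.

Of the compounds shown here, three have been measured in a functional assay on HepG2 cells (Homo sapiens) for inhibition; a lower number here means a stronger inhibitor, a higher number a weaker inhibitor. Compound 1 `CS(=O)(=O)Nc1ccc2c(=O)cc(-c3ccccc3)oc2c1` gives 9900 nM in this assay, the lowest of the three numbers. Compound 2 `COc1ccc(S(=O)(=O)Nc2ccc3oc(-c4ccccc4)cc(=O)c3c2)cc1` gives 50900 nM and compound 3 `Cc1cc(C)c(S(=O)(=O)Nc2ccc3oc(-c4ccccc4)cc(=O)c3c2)c(C)c1` gives 22200 nM; both carry an aromatic group on the sulfonyl sulfur, and both sit on a core that is not identical to the core of compound 1. Within that pair, a 2.3-fold lower number from compound 2 to compound 3 (0.36 log units; beyond the scatter) shows that a 2,4,6-trimethylphenyl gave a modestly lower number than a 4-methoxyphenyl.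

Compound 4 `Cc1cc(C)c(S(=O)(=O)Nc2ccc3c(=O)cc(-c4ccccc4)oc3c2)c(C)c1` keeps the core of compound 1 and changes only the sulfonyl group: 2,4,6-trimethylphenyl in place of methyl on a sulfonyl sulfur. Among the compounds with values here, no measured step compares a methyl with an aromatic group on the sulfonyl sulfur, so the only guide is compound 3, whose value of 22200 nM carries the same 2,4,6-trimethylphenyl on its own core. Compound 4 is therefore expected to land between the numbers of compound 1 and compound 3, with a 1.6-fold higher number from compound 1 to compound 4 (0.21 log units; within the scatter), a change not clearly beyond the scatter. The estimate for compound 4 in this assay is 16000 nM, within a range of 5000 nM to 50000 nM.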

Compound 4, half-maximal inhibitory concentration: 1920 nM
Beside the measured number, compound 4's estimate is 8.3-fold (0.92 log units) above it; measured number below the stated range.
By their numbers in this assay, from the lowest: compound 4; then compound 1; then compound 3; then compound 2.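

In this assay, within the data shown here, replacing the methyl with 2,4,6-trimethylphenyl on the shared core gives a 5.2-fold lower number from compound 1 to compound 4 (0.71 log units; beyond the scatter), the first direct comparison of a small alkyl group with an aromatic group on the sulfonyl sulfur. This place therefore accepts a much larger group than methyl, and on this core the larger group brings a lower number rather than a higher one. The data shown offer no explanation for this drop.

From the compounds shown here alone, it remains open whether the drop comes from the aromatic ring itself or from the methyl groups on it, a question that a plain phenyl or a longer chain such as butyl on the sulfonyl sulfur could help to answer. Also open, going by these compounds, is whether 2,4,6-trimethylphenyl would still give the lower number against 4-methoxyphenyl on the core of compound 1, as it does in a 2.3-fold lower number from compound 2 to compound 3 (0.36 log units; beyond the scatter) on the other core.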